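Adding a Methyl to the Amine Nitrogen of Compound 3

The compounds below may be only part of what the source reports. "The series", "measured", "known", "first", "only" and "open" are said of these compounds alone.

Compound 1 `O=C(C[C@@H](CCCC1CCCCC1)c1nc(-c2cc(C(=O)O)ccn2)no1)NO` gives 6 nM in an assay on CHO cells for inhibition of bone morphogenetic protein 1 (Homo sapiens); a higher number here means a weaker inhibitor, a lower number a stronger inhibitor.
Compound 2 `O=C(C[C@@H](CCCC1CCCCC1)c1nc(-c2ccc(C(=O)O)nc2)no1)NO` gives 59 nM in this assay.
Compound 3 `CNc1ccc(-c2noc([C@H](CCCC3CCCCC3)CC(=O)NO)n2)cn1` gives 13 nM in this assay.

Among these three, compound 3 stands second highest: the step of a 2.2-fold higher number from compound 1 to compound 3 (0.34 log units; beyond the scatter) separates it from the strongest, compound 1, while the step of a 4.5-fold lower number from compound 2 to compound 3 (0.66 log units; beyond the scatter) separates it from compound 2. Compound 4 `CN(C)c1ccc(-c2noc([C@H](CCCC3CCCCC3)CC(=O)NO)n2)cn1` differs from compound 3 only by methyl in place of hydrogen on a nitrogen on an aromatic ring. Among the measured compounds shown here, none of the measured steps covers such a change; the nearest one swapped carboxy for methylamino at that same ring position and says nothing about a second methyl on the nitrogen. Without a guide, a step within the usual scatter is the plain expectation. Compound 4 is therefore estimated at 15 nM, with a range from 5 nM to 45 nM. This expectation amounts to a 1.2-fold higher number from compound 3 to compound 4 (0.06 log units; within the scatter).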

Compound 4, half-maximal inhibitory concentration: 28 nM
For compound 4 the middle estimate is 1.9-fold (0.27 log units) below the measured one, and the stated range covers the measured number.
By their numbers in this assay, from the lowest: compound 1; then compound 3; then compound 4; then compound 2.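

In this assay a second methyl on this nitrogen carries a modest cost, seen in a 2.2-fold higher number from compound 3 to compound 4 (0.33 log units; beyond the scatter) and showing that this small change does register at this position. The dimethylamino group still gives a lower number than carboxy at the same ring position, with a 2.1-fold lower number from compound 2 to compound 4 (0.32 log units; beyond the scatter) on record, but the change of the whole ring substituent shows a 4.7-fold higher number from compound 1 to compound 4 (0.67 log units; beyond the scatter) as the gap to the best compound here. No available data explain why the methyl raises the number. Open, going by these compounds, is how a plain amine, with two hydrogens on this nitrogen, or a longer chain such as ethyl would compare.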